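The source may hold more compounds than are shown below. What is called first, only, known or untested is meant among the compounds shown, and "the series" means these compounds.

Measured in an assay on CHO cells for binding affinity to adenosine receptor A2b (Homo sapiens), with a stated time of 20 min; a higher number here means a weaker inhibitor, a lower number a stronger inhibitor:
Compound 1 `Cn1c(=O)c2[nH]c(Cc3ccc(OCCCCl)cc3)nc2n(C)c1=O` gives > 10 nM, which is a limit of the assay and not a number.
Compound 2 `Cn1c(=O)c2[nH]c(-c3ccc(OCCCN4CCN(Cc5ccccc5Cl)CC4)cc3)nc2n(C)c1=O` gives 0.17 nM.
Compound 3 `Cn1c(=O)c2[nH]c(Cc3ccc(OCCCN4CCC5(CC4)OCCO5)cc3)nc2n(C)c1=O` gives > 10 nM, again a limit of the assay.

Compound 3 therefore stands at the limit of > 10 nM in this assay, at which 2 of the 3 values shown sit. Within the data shown here, the one single-change step, a step that the two limits leave unreadable from compound 1 to compound 3, is unreadable for that reason. Among the measured compounds shown here, compound 2 differs from compound 3 in more than one place, so no step connects them; its value shows only that a strong binder exists in the set.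

Compound 4 `Cn1c(=O)c2[nH]c(Cc3ccc(OCCCn4ccnc4)cc3)nc2n(C)c1=O` carries the change (a group of 5 heavy atoms (3 carbon, 2 nitrogen; one five-membered aromatic ring with 2 hetero atoms) in place of a group of 10 heavy atoms (7 carbon, 1 nitrogen, 2 oxygen; one five-membered non-aromatic ring with 2 hetero atoms, one six-membered non-aromatic ring with 1 hetero atom), on a saturated chain carbon, three bonds along the chain from an oxygen on an aromatic ring). For the measured compounds named here, no measured step bears readably on this exchange, and with compound 1 and compound 3 both at the limit, compound 4 is expected to remain weak, likely again as a limit. Compound 4 is estimated at 30 nM, between 8 nM and 300 nM, an expected step that the limit leaves unreadable from compound 3 to compound 4.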

Compound 4, inhibition constant: > 10 nM
Compound 4 gave a limit, no number; the forecaster's own chance of this, stated with the estimate: 60%; the middle value does not contradict the limit.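

The steps among compound 1, compound 3 and compound 4 cannot be read, since all three values are limits of the assay and not numbers: the limit of > 10 nM in this assay, at which 3 of the 4 values shown sit.

Still open, on these data alone, is how strongly these three bind, and which single change would connect any of them to compound 2.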